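A few compounds are considered here, and "the series" means these few. Any claim that something is new, unique, unknown or untested is made for them only; others in the source may bear on it.

In an assay on isolated protein for inhibition of protein deacetylase HDAC6 (Homo sapiens) (on this read-out lower numbers stand for stronger inhibition and higher numbers for weaker inhibition), compound 3 `O=C(c1ccc(-c2nc(-c3ccc(F)cc3F)no2)s1)C(F)(F)F` gives 580 nM, the highest of the three numbers recorded so far, while compound 1 `O=C(c1ccc(-c2nc(-c3ccccn3)no2)s1)C(F)(F)F` gives 500 nM and compound 2 `O=C(c1ccc(-c2nc(Cc3cccs3)no2)s1)C(F)(F)F` gives 170 nM. The step of a 1.2-fold higher number from compound 1 to compound 3 (0.06 log units; within the scatter) lies within the scatter, whereas a 3.4-fold higher number from compound 2 to compound 3 (0.53 log units; beyond the scatter) and a 2.9-fold lower number from compound 1 to compound 2 (0.47 log units; beyond the scatter) lie beyond it. Compound 4 `O=C(c1ccc(-c2nc(-c3ccc(Cl)cc3Cl)no2)s1)C(F)(F)F` differs from compound 3 by 2,4-dichlorophenyl in place of 2,4-difluorophenyl on an aromatic carbon. Among the compounds with values here, the step that bears on this position most directly, pyridin-2-yl giving way to 2,4-difluorophenyl, moved nothing beyond the scatter, and no measured pair sets chlorine against fluorine. A step of a 1.3-fold lower number from compound 3 to compound 4 (0.11 log units; within the scatter) is therefore expected, not beyond the scatter. Compound 4 is estimated at 450 nM, in the range 180 nM to 1100 nM.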

Compound 4, half-maximal inhibitory concentration: 3000 nM
For compound 4 the middle estimate is 6.7-fold (0.82 log units) below the measured one, and the stated range ends below it.
By their numbers in this assay, from the lowest: compound 2; then compounds 1 and 3 (each within the scatter of the next); then compound 4.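

In this assay this position proves sensitive to the halogens on the phenyl ring: a 5.2-fold higher number from compound 3 to compound 4 (0.71 log units; beyond the scatter) is beyond the scatter, although pyridin-2-yl and 2,4-difluorophenyl had not been separated. The 2,4-dichlorophenyl group also stands apart from the other two groups, with a 6.0-fold higher number from compound 1 to compound 4 (0.78 log units; beyond the scatter) and an 18-fold higher number from compound 2 to compound 4 (1.25 log units; beyond the scatter) both beyond the scatter. Nothing available accounts for the change from fluorine to chlorine. As far as these compounds go, whether a single chlorine on the phenyl ring would carry the same step remains open, as does where 2,4-dimethylphenyl or 2,4-dimethoxyphenyl would fall.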